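Ester variation on the nitroanilide series

The compounds below may be only part of what the source reports. "The series", "measured", "known", "first", "only" and "open" are said of these compounds alone.

Measured so far:
- compound 1 `O=C(OC1(C(=O)Nc2ccc([N+](=O)[O-])cc2)CCCCC1)c1ccc(Cl)cc1`: 10.3 nM
- compound 2 `O=C(OC1(C(=O)Nc2ccc([N+](=O)[O-])cc2)CCCCC1)c1ccc(Br)cc1`: 236 nM

For the measured compounds named here, in a functional assay on NFS-60 cells (Mus musculus) for inhibition, read by MTT assay, with a stated time of 72 h (on this read-out lower numbers stand for stronger inhibition and higher numbers for weaker inhibition), compound 2 gives the highest of the two numbers, with compound 1 the nearest point and the only comparison. Going by the values given here, the one measured step, a 23-fold higher number from compound 1 to compound 2 (1.36 log units; beyond the scatter), is a halogen swap on the ester aryl ring and was large.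

Compound 3 `O=C(/C=C/c1ccccc1)OC1(C(=O)Nc2ccc([N+](=O)[O-])cc2)CCCCC1` replaces the ester aryl group entirely: 2-phenylethenyl in place of 4-bromophenyl on a carbonyl carbon. Among the compounds with values here, no measured step covers this kind of change; the halogen swap tells only that the ester aryl part is sensitive, not in which direction a 2-phenylethenyl group will move the number. The estimate for compound 3 therefore sits between the two measured values, with the step of a 2.6-fold lower number from compound 2 to compound 3 (0.42 log units; beyond the scatter) expected but wide. Compound 3 is estimated at 90 nM, in the range 15 nM to 800 nM.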

Compound 3, half-maximal inhibitory concentration: 50.5 nM
Estimate against measurement, compound 3: 1.8-fold (0.25 log units) above, within the range that was stated.
By their numbers in this assay, from the lowest: compound 1; then compound 3; then compound 2.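

In this assay the ester aryl group can give way to 2-phenylethenyl on the carbonyl carbon with a 4.7-fold lower number from compound 2 to compound 3 (0.67 log units; beyond the scatter) and with a 4.9-fold higher number from compound 1 to compound 3 (0.69 log units; beyond the scatter) as the two readings of the change, so the new ester falls inside the span set by the two halogenated esters. The direction of this replacement therefore depends on the reference: it is a gain against 4-bromophenyl and a loss against 4-chlorophenyl, and no single ranking of the two kinds of group holds across both pairs. Nothing available explains these differences in the numbers.

Open, as far as these compounds go, is whether the double bond itself matters, which a saturated 2-phenylethyl ester would address. Also open, from the compounds shown here alone, is how this position responds to a 4-fluorophenyl ester, or to a group with no aromatic ring, such as cyclohexyl or a plain alkyl chain.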